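A few compounds are considered here, and "the series" means these few. Any claim that something is new, unique, unknown or untested is made for them only; others in the source may bear on it.

Measured compounds:
Compound 1 `CCN1C(=O)N(CC)C2C1NC(=S)N2/N=C/C=C/c1ccccc1` gives 42100 nM in an ADME assay on HEK293 cells (Homo sapiens) for inhibition, read by MTT assay, with a stated time of 72 h; on this read-out higher numbers stand for weaker inhibition and lower numbers for stronger inhibition.
Compound 2 `CCN1C(=O)N(CC)C2C1NC(=S)N2/N=C/C=C/c1ccccc1[N+](=O)[O-]` gives 19300 nM in this assay.
Compound 3 `CCN1C(=O)N(CC)C2C1NC(=O)N2/N=C/C=C/c1ccccc1` is recorded as "not active" (no number reported) in this assay, with no number.

Compound 1 and compound 2 differ in one place: nitro in place of hydrogen on an aromatic carbon. That change made a 2.2-fold lower number from compound 1 to compound 2 (0.34 log units; beyond the scatter), a modest gain in inhibition. Compound 4 `CCN1C(=O)N(CC)C2C1NC(=O)N2/N=C/C=C/c1ccccc1[N+](=O)[O-]` stands to compound 3 exactly as compound 2 stands to compound 1: nitro in place of hydrogen on an aromatic carbon. The place of the change is the same in both pairs, so this is the same change. How the core of compound 1 differs from the core of compound 3 is not broken down here.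

Since compound 3 has no number in this assay, only a report of no activity, the step cannot be applied to a measured starting point. The expectation for compound 4 therefore rests on the size of a 2.2-fold lower number from compound 1 to compound 2 (0.34 log units; beyond the scatter), which is too small to turn an inactive compound into a clearly active one. Compound 4 is expected to be weak or inactive, with an estimated value of 90000 nM and a range from 30000 nM to 300000 nM.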

Compound 4, half-maximal inhibitory concentration: 42900 nM
The estimate for compound 4 lay 2.1-fold (0.32 log units) above the measured number, within the range that was stated.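

Compound 3 is recorded only as not active in this assay, with no number, so the change from compound 3 to compound 4 cannot be read as a step. The compounds shown leave open how large the effect of the nitro group is on the core of compound 3. No measurement shown explains the activity of compound 4.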